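Oxan-4-yl for isobutyl on the aromatic nitrogen

The source may hold more compounds than are shown below. What is called first, only, known or untested is meant among the compounds shown, and "the series" means these compounds.

In a physicochemical assay for lipophilicity, using the shake flask method, measured as octanol-water partition, at pH 7.4 (a higher number here means a more lipophilic compound, a lower number a more polar compound), compound 1 (`CNC(=O)CN1CCC(c2cc3c(-c4ccc(=O)n(C(C)C)c4)ccnc3[nH]2)CC1`) gives 2.2, compound 2 (`CC(=O)N1CCC(c2cc3c(-c4ccc(=O)n(C(C)C)c4)ccnc3[nH]2)CC1`) gives 2.1 and compound 3 (`CC(C)Cn1cc(-c2ccnc3[nH]c(C4CCN(CC(=O)N(C)C)CC4)cc23)ccc1=O`) gives 2. All three lie within the scatter of one another. The change leading to compound 4 (`CN(C)C(=O)CN1CCC(c2cc3c(-c4ccc(=O)n(C5CCOCC5)c4)ccnc3[nH]2)CC1`) is oxan-4-yl in place of isobutyl on an aromatic nitrogen. Among the measured compounds shown here, the only measured single-place step is a number 0.10 log units lower from compound 1 to compound 2 (within the scatter), with acetyl in place of (methylcarbamoyl)methyl on an amine nitrogen in a ring. It concerns a different nitrogen and gives no size for this change. The expectation therefore rests on the structural change alone, with an oxygen entering, and points to a lower number in this assay. The expected step is a number 0.70 log units lower from compound 3 to compound 4 (beyond the scatter). For compound 4 the estimate is 1.3, with an expected range from 0.9 to 1.7.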

Compound 4, distribution coefficient: 1.1
Compound 4: middle estimate off by 0.20 log units, on the high side; the measured number falls inside the stated range.
By their numbers in this assay, from the lowest: compound 4; then compounds 3, 2 and 1 (each within the scatter of the next).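

In this assay oxan-4-yl in place of isobutyl on the aromatic nitrogen gives a number 0.90 log units lower from compound 3 to compound 4 (beyond the scatter) and is the only single-place step shown that lies beyond the scatter. The other step, a number 0.10 log units lower from compound 1 to compound 2 (within the scatter) on the amine nitrogen in a ring, stays within it. No measurement available here accounts for the size of the new step.

Oxan-4-yl brings both a ring and an oxygen, and the compounds shown do not separate the two. Cyclohexyl on the same nitrogen would separate them.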